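Naphthalen-2-yl in place of 4-phenylphenyl: working notes

The source may hold more compounds than are shown below. What is called first, only, known or untested is meant among the compounds shown, and "the series" means these compounds.

Measured in a functional assay on BGC-823 cells (Homo sapiens) for inhibition, read by MTT assay, with a stated time of 72 h; on this read-out lower numbers stand for stronger inhibition and higher numbers for weaker inhibition:
- compound 1 `O=C1/C(=C\c2ccccc2)c2c(ncn2COCc2ccccc2)CCN1Cc1ccc(-c2ccccc2)cc1`: 81000 nM
- compound 2 `O=C1/C(=C\c2ccncc2)c2c(ncn2COCc2ccccc2)CCN1Cc1ccccc1`: > 100000 nM (a limit, not a number)
- compound 3 `O=C1/C(=C\c2ccc(C(F)(F)F)cc2)c2c(ncn2COCc2ccccc2)CCN1Cc1ccccc1`: 42600 nM

Compound 1 and compound 3 lie within the scatter of each other. Compound 4 `O=C1/C(=C\c2ccccc2)c2c(ncn2COCc2ccccc2)CCN1Cc1ccc2ccccc2c1` carries naphthalen-2-yl in place of 4-phenylphenyl on a saturated chain carbon bound to an amide-type nitrogen in a ring. Among the compounds with values here, the only measured step, an at least 2.3-fold lower number from compound 2 to compound 3 (0.37 log units; beyond the scatter), sits at another place, on a double-bonded chain carbon bound to a double-bonded ring carbon, and gives no size for this change. Resting on compound 1 at 81000 nM, no step beyond the scatter is expected in this assay. The expected step is a 1.2-fold lower number from compound 1 to compound 4 (0.10 log units; within the scatter). For compound 4 the estimate is 65000 nM, with an expected range of 25000 nM to 100000 nM.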

Compound 4, half-maximal inhibitory concentration: 93300 nM
Compound 4: middle estimate off by 1.4-fold (0.16 log units), on the low side, and the stated range covers the measured number.
By their numbers in this assay, from the lowest: compounds 3, 1 and 4 (each within the scatter of the next, the first and the last beyond it). At a limit, above all of these: compound 2.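

In this assay, within the data shown here, naphthalen-2-yl in place of 4-phenylphenyl gives a 1.2-fold higher number from compound 1 to compound 4 (0.06 log units; within the scatter), the first measured step on this saturated chain carbon bound to an amide-type nitrogen in a ring. Each with 2 six-membered aromatic rings of carbon only, the two groups are not told apart here. Compound 2 gives a limit, not a number: the limit of > 100000 nM in this assay, at which 1 of the 4 values shown sits.

Going by these compounds, whether an amine or a carboxylic acid at this place would move the number beyond the scatter stays open. Also open, on these data alone, is how 4-(trifluoromethyl)phenyl on the double-bonded chain carbon reads with naphthalen-2-yl present.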